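This account rests on a few compounds, and the source may have more. Where it says the series, first, only, none or still open, it means among the compounds named here.

Working notes on the series. Compound 3, `Cc1ccccc1Nc1nc(SCc2cn(CC(=O)NC(=O)Nc3ccccn3)nn2)nc(-c2ccc(C(C)C)cc2)c1C#N`, sits in a functional assay on MCF7 cells (Homo sapiens) for inhibition, read by MTT assay, with a stated time of 72 h (a lower number here means a stronger inhibitor, a higher number a weaker inhibitor), at a limit of the assay, > 64000 nM. Compound 1, `CC(C)c1ccc(-c2nc(SCc3cn(CC(=O)NC(=O)Nc4ccccn4)nn3)nc(Nc3ccc(F)cc3)c2C#N)cc1`, sits at the same limit in this assay, > 64000 nM. Compound 2, `CC(C)c1ccc(-c2nc(SCc3cn(CC(=O)NC(=O)Nc4ccccn4)nn3)nc(Nc3cccc([N+](=O)[O-])c3)c2C#N)cc1`, gives 25900 nM in this assay. The readable steps are an at least 2.4-fold lower number from compound 1 to compound 2 (0.39 log units; beyond the scatter) and an at least 2.4-fold higher number from compound 2 to compound 3 (0.39 log units; beyond the scatter); the step that the two limits leave unreadable from compound 1 to compound 3. Two of the three values rest at the limit of > 64000 nM in this assay, at which 2 of the 3 values shown sit.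

Compound 4 is `CC(C)c1ccc(-c2nc(SCc3cn(CC(=O)NC(=O)Nc4ccccn4)nn3)nc(Nc3ccccc3O)c2C#N)cc1`; it differs from compound 3 by hydroxy in place of methyl on an aromatic carbon. Within the data shown here, no measured pair swaps these two groups, so nothing anchors the size of this step. Among the measured compounds shown here, compound 3 stands at a limit, > 64000 nM, and no measured step is large enough to suggest a move into the readable range. The step that the limit leaves unreadable from compound 3 to compound 4 is expected to remain within the scatter. Compound 4 is therefore estimated at 70000 nM, between 20000 nM and 250000 nM, most likely reported again only as a limit.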

Compound 4, half-maximal inhibitory concentration: > 64000 nM
Compound 4: no number, only a limit (the forecaster's own chance of this, stated with the estimate: 70%); the middle value lies beyond the limit too.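

Compound 4, with 2-hydroxyphenyl on the nitrogen, gives > 64000 nM in this assay, which is a limit and not a number, so a hydroxy ortho to a large group leaves this position as unresolved as methyl did. Among these compounds, compound 2 stays the only compound with a number, with an at least 2.4-fold higher number from compound 2 to compound 4 (0.39 log units; beyond the scatter). The steps from compound 4 to compound 1 and compound 3 cannot be read, and the limit now holds most of the series: the limit of > 64000 nM in this assay, at which 3 of the 4 values shown sit.

On these data alone, whether an amine or a carboxylic acid on this ring would give a number stays open. So does whether 2-nitrophenyl or 4-nitrophenyl would read like 3-nitrophenyl.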